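Chloro for methoxy on the benzyl arm of compound 1

The source may report more compounds than this note shows. Statements on the series, on what has been measured and on what is new or still open speak of the compounds shown alone.

Measured compounds:
compound 1 `COc1ccc(CN(C(=O)CSC(=S)N2CCN(C(=O)OC(C)(C)C)CC2)c2cc(OC)c(OC)c(OC)c2)cc1` — 620 nM
compound 2 `COc1ccc(CN(C(=O)CSC(=S)N2CCN(C(=O)OC(C)(C)C)CC2)c2ccc(Cl)cc2)cc1` — > 20000 nM
compound 3 `COc1ccc(CN(C(=O)CSC(=S)N2CCN(C(=O)OC(C)(C)C)CC2)c2ccc(OC)cc2)cc1` — > 20000 nM

Within the data shown here, in a functional assay on HCT-116 cells (Homo sapiens) for inhibition, read by CCK-8 assay, with a stated time of 48 h (on this read-out higher numbers stand for weaker inhibition and lower numbers for stronger inhibition), compound 1 gives 620 nM, the only number in the set. For compound 2 the read-out in this assay is a limit of the assay, > 20000 nM, not a number. For compound 3 the read-out in this assay is likewise a limit, > 20000 nM. Both rest at the limit of > 20000 nM in this assay, at which 2 of the 3 values shown sit. Against compound 1 these give an at least 32-fold higher number from compound 1 to compound 2 (1.50 log units; beyond the scatter) and an at least 32-fold higher number from compound 1 to compound 3 (1.50 log units; beyond the scatter), so the 3,4,5-trimethoxyphenyl on the amide-type nitrogen carries the measurable inhibition here.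

The change of interest is chloro in place of methoxy on an aromatic carbon. Its step, a step that the two limits leave unreadable from compound 3 to compound 2, cannot be sized, as both ends are limits. Compound 4 `COc1cc(N(Cc2ccc(Cl)cc2)C(=O)CSC(=S)N2CCN(C(=O)OC(C)(C)C)CC2)cc(OC)c1OC` carries the same kind of change against compound 1, namely (chloro in place of methoxy on an aromatic carbon). The two cores differ by 3,4,5-trimethoxyphenyl in place of 4-methoxyphenyl on an amide-type nitrogen. The place descriptions agree word for word, though cut one bond further out the change on compound 1 also reads 4-methoxybenzyl to 4-chlorobenzyl, which the change on compound 3 does not.

Since compound 4 keeps the 3,4,5-trimethoxyphenyl, and the methoxy-to-chloro step on compound 3 left no readable size, a small step is expected, a 1.5-fold higher number from compound 1 to compound 4 (0.16 log units; within the scatter). Compound 4 is estimated at 900 nM in this assay, expected between 300 nM and 3000 nM.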

Compound 4, half-maximal inhibitory concentration: 8490 nM
Estimate against measurement, compound 4: 9.4-fold (0.97 log units) below, outside the stated range (above it).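

In this assay, with the 3,4,5-trimethoxyphenyl kept on the amide-type nitrogen, going from 4-methoxybenzyl to 4-chlorobenzyl gives a 14-fold higher number from compound 1 to compound 4 (1.14 log units; beyond the scatter), so on this core the chloro does not stand in for the methoxy without a large loss of inhibition. The same kind of change on the core carrying a 4-methoxybenzyl and a 4-methoxyphenyl, from compound 3 to compound 2, cannot be read, because both ends are limits and not numbers: the limit of > 20000 nM in this assay, at which 2 of the 4 values shown sit. The result therefore gives one readable size on one core and does not show whether that size carries to another core, all the more as the change on compound 3 falls on the 4-methoxyphenyl and not on the 4-methoxybenzyl.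

Open, going by these compounds, is how the 4-chlorobenzyl behaves on a core with a 4-methoxyphenyl on the amide-type nitrogen, which would put the change at the same place on both cores. Also open, on these data alone, is whether a fluoro, a hydroxy or an amine at that place on the benzyl arm of compound 1 stays closer to compound 1 than the chloro of compound 4 does.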